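The compounds below may be only part of what the source reports. "The series", "measured", "known", "first", "only" and "open" are said of these compounds alone.

Compound 1 `Cc1ccc(-c2ccc(CN3CCC(O)(Cn4cnc5c(-c6ccc(CN)cc6)n(C)nc5c4=O)CC3)c(Cl)c2)s1` is examined in an assay on isolated protein for inhibition of ubiquitin carboxyl-terminal hydrolase 7 (Homo sapiens), with stated times of 30 min and 2 h (on this read-out lower numbers stand for stronger inhibition and higher numbers for weaker inhibition), and gives 101 nM, the highest of the three numbers gathered so far. Compound 2 `CCNCc1ccc(-c2c3ncn(CC4(O)CCN(Cc5ccc(-c6ccco6)cc5Cl)CC4)c(=O)c3nn2C)cc1` gives 15.2 nM in this assay, and compound 3 `Cn1nc2c(=O)n(CC3(O)CCN(Cc4ccc(-c5ccco5)cc4Cl)CC3)cnc2c1-c1ccc(CNC2CC2)cc1` gives 54.1 nM. Compound 1 thus stands nearest to compound 3, within the scatter of the method, and furthest from compound 2, beyond it. Among the measured compounds shown here, the single step measured within this set, a 3.6-fold higher number from compound 2 to compound 3 (0.55 log units; beyond the scatter), concerns the amine substituent and not the aryl ring. Compound 4 `Cn1nc2c(=O)n(CC3(O)CCN(Cc4ccc(-c5ccc[nH]5)cc4Cl)CC3)cnc2c1-c1ccc(CN)cc1` differs from compound 1 by 1H-pyrrol-2-yl in place of 5-methylthiophen-2-yl on an aromatic carbon. For the measured compounds named here, no measured step bears on this change: compounds 2 and 3 carry both a different five-membered ring and a different amine, so their numbers cannot be read as the effect of the ring alone. With nothing to lean on, the expected step of a 1.2-fold higher number from compound 1 to compound 4 (0.07 log units; within the scatter) is none beyond the scatter. Compound 4 is therefore estimated at 120 nM, within a range from 40 nM to 400 nM.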

Compound 4, half-maximal inhibitory concentration: 193 nM
Compound 4: middle estimate off by 1.6-fold (0.21 log units), on the low side; the measured number falls inside the stated range.
By their numbers in this assay, from the lowest: compound 2; then compounds 3, 1 and 4 (each within the scatter of the next, the first and the last beyond it).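

In this assay, among the compounds shown here, putting 1H-pyrrol-2-yl in place of 5-methylthiophen-2-yl gives a 1.9-fold higher number from compound 1 to compound 4 (0.28 log units; within the scatter), the first measured step at this aromatic carbon. The exchange removes one heavy atom, swaps sulfur for nitrogen, and replaces a hydrogen-bond acceptor with a donor, yet the step stays within the scatter, so this pair shows no clear difference between the two rings. No measurement of structure or mechanism is available to explain this result.

Going by these compounds, it remains open whether the hydrogen on the pyrrole nitrogen or the methyl on the thiophene contributes at all, a question that 1-methylpyrrol-2-yl or unsubstituted thiophen-2-yl on the same core could address. The furan-2-yl of compound 2 and compound 3 also remains unseparated from their substituted amines, so its own contribution at this position cannot be read.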